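A few compounds are considered here, and "the series" means these few. Any claim that something is new, unique, unknown or untested is made for them only; others in the source may bear on it.

Measured so far:
compound 1 `CCCC(=O)C1=C(C)NC(=O)NC1c1cccs1` — 2%
compound 2 `CC1=C(C(=O)OC2CCC2)C(c2ccco2)NC(=O)N1` — 19%

In an assay on membranes from CHO cells for displacement of a labelled ligand from adenosine receptor A1 (Homo sapiens), read by scintillation counting, with a stated time of 60 min, tested at 1 uM (a higher number here means more inhibition at the concentration tested (going by the name of the read-out), a lower number less inhibition), compound 1 gives 2% and compound 2 gives 19%. Compound 2 stands highest of the two numbers; its nearest neighbour is compound 1, which lies lower by a gap beyond the usual scatter. Among the compounds with values here, no pair differing in a single place has been measured, so no step size is known.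

Compound 3 `CC1=C(C(=O)OC2CCC2)C(c2cccs2)NC(=O)N1` follows from compound 2 by one change: thiophen-2-yl in place of furan-2-yl on a saturated ring carbon. Both rings keep one hetero atom and the rest of the structure is untouched. Within the data shown here, with no measured step of this kind to lean on, the expectation is a step of no size beyond the scatter, in no clear direction. Compound 3 is therefore expected to give about 20% in this assay, within 5% to 40%, meaning an expected step of a number 1 percentage points higher from compound 2 to compound 3 (within the scatter).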

Compound 3, a percentage reported as inhibition, at one concentration (the size of the read-out at that concentration, not a potency): 24%
Compound 3: middle estimate off by 4 percentage points, on the low side; measured number inside the range.
By their numbers in this assay, from the lowest: compound 1; then compounds 2 and 3 (each within the scatter of the next).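

In this assay thiophen-2-yl in place of furan-2-yl on the saturated ring carbon gives a number 5 percentage points higher from compound 2 to compound 3 (within the scatter) and so shows that, with cyclobutyloxy on the carbonyl carbon, this exchange makes no difference that can be told from scatter. Within the data shown here, the thiophen-2-yl pair also gives the first reading at the carbonyl carbon: cyclobutyloxy in place of propyl gives a number 22 percentage points higher from compound 1 to compound 3 (beyond the scatter) and is a modest step, so the change at this carbon, not the ring exchange, is the one that registers so far. Nothing available bears on the cause of either step.

Still open, as far as these compounds go, is what phenyl or an amine would give on the saturated ring carbon. Also open, from the compounds shown here alone, is whether a longer alkoxy chain on the carbonyl carbon would carry the step further, and whether the propyl to cyclobutyloxy step holds with furan-2-yl.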